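This account rests on a few compounds, and the source may have more. Where it says the series, first, only, none or still open, it means among the compounds named here.

Measured compounds:
- compound 1 `COc1cc(F)ccc1-c1ccnc2[nH]c(C3CCN(CC(=O)N(C)C)CC3)cc12` gives 38 uL/min
- compound 2 `CC(C)n1nc(-c2ccnc3[nH]c(C4CCN(CC(=O)N(C)C)CC4)cc23)ccc1=O` gives 3.1 uL/min
- compound 3 `CC(C)n1cc(-c2ccnc3[nH]c(C4CCN(CC(=O)N(C)C)CC4)cc23)ccc1=O` gives 2.3 uL/min

In an ADME assay on cells (Hepatocyte, Rattus norvegicus) for metabolic stability (on this read-out higher numbers stand for fast clearance and lower numbers for slow clearance), compound 3 stands at the lowest of the three numbers; the gap to compound 2 lies within the scatter, while compound 1 sits far above it. The measured steps of a 12-fold lower number from compound 1 to compound 2 (1.09 log units; beyond the scatter) and a 17-fold lower number from compound 1 to compound 3 (1.22 log units; beyond the scatter) were large, whereas a 1.3-fold lower number from compound 2 to compound 3 (0.13 log units; within the scatter) stayed within the scatter. Compound 4 `COc1cc(=O)n(C)cc1-c1ccnc2[nH]c(C3CCN(CC(=O)N(C)C)CC3)cc12` is built from compound 3 by a change at the same ring: a group of 10 heavy atoms (7 carbon, 1 nitrogen, 2 oxygen; one six-membered aromatic ring with 1 hetero atom) in place of a group of 10 heavy atoms (8 carbon, 1 nitrogen, 1 oxygen; one six-membered aromatic ring with 1 hetero atom), on an aromatic carbon. The two prior exchanges at this position that kept a six-membered aromatic ring with a ring nitrogen and a double bond outside the aromatic ring gave two nearly equal low numbers, so an exchange of this kind, keeping that ring type, is expected to move little in this assay: a step of a 1.1-fold higher number from compound 3 to compound 4 (0.04 log units; within the scatter) is estimated, not beyond the scatter in either direction. Compound 4 is therefore expected to give about 2.5 uL/min, with a range from 1 uL/min to 6 uL/min.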

Compound 4, intrinsic clearance in a liver preparation (reported as CLH), per the amount of preparation that the assay uses: < 1 uL/min
Compound 4 ended at the assay's limit; the forecaster's own chance of this, stated with the estimate: 5%; at least 2.5-fold (0.39 log units) between middle value and limit.
By their numbers in this assay, from the lowest: compounds 3 and 2 (each within the scatter of the next); then compound 1. At a limit, below all of these: compound 4.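

In this assay, compound 4 gives a limit and not a number: the limit of < 1 uL/min in this assay, at which 1 of the 4 values shown sits. The earlier exchange at this position, a 1.3-fold lower number from compound 2 to compound 3 (0.13 log units; within the scatter), suggested that it had nothing further to give, yet an at least 2.3-fold lower number from compound 3 to compound 4 (0.36 log units; beyond the scatter) and an at least 3.1-fold lower number from compound 2 to compound 4 (0.49 log units; beyond the scatter) both lie beyond the scatter, so the number still responds here even among groups with one six-membered aromatic ring and a double bond outside it. With an at least 38-fold lower number from compound 1 to compound 4 (1.57 log units; beyond the scatter), the group of compound 4 also gives the widest step shown from the carbon-only aromatic ring of compound 1, though all three steps are bounded by the limit and their full size stays unknown.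

The compounds shown leave open how far under the limit compound 4 lies and which part of its entering group goes with the step. On these data alone, whether an amine or a nitrile on the same ring would hold the number as low is also open.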